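The compounds below may be only part of what the source reports. "The series", "measured", "known", "first", "only" and "open" are said of these compounds alone.

Of the compounds shown here, three have been measured and a fourth awaits its result. Compound 1 `COc1ccc(OC)c(C(=O)/C=C/c2cn(-c3ccccc3)nc2-c2cccnc2)c1` was tested in a functional assay on MCF7 cells (Homo sapiens) for inhibition, read by sulforhodamine B assay, with a stated time of 72 h (on this read-out higher numbers stand for weaker inhibition and lower numbers for stronger inhibition), and gave 1500 nM. Compound 2 `COc1ccc(C(=O)/C=C/c2cn(-c3ccccc3)nc2-c2cccnc2)c(OC)c1` differs from compound 1 in that (2,4-dimethoxyphenyl in place of 2,5-dimethoxyphenyl on a carbonyl carbon); in this assay compound 2 gives 2300 nM, so that a 1.5-fold higher number from compound 1 to compound 2 (0.19 log units; within the scatter). Compound 3 `COc1ccc(OC)c(C(=O)/C=C/c2cn(-c3ccccc3)nc2-c2ccncc2)c1` differs from compound 1 in that (pyridin-4-yl in place of pyridin-3-yl on an aromatic carbon); in this assay compound 3 gives 1400 nM, and thus a 1.1-fold lower number from compound 1 to compound 3 (0.03 log units; within the scatter). All three numbers lie within the usual scatter of one another, so no order among them can be claimed.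

Compound 4 `COc1ccc(C(=O)/C=C/c2cn(-c3ccccc3)nc2-c2ccncc2)c(OC)c1` has not yet been measured. It differs from compound 3 in that (2,4-dimethoxyphenyl in place of 2,5-dimethoxyphenyl on a carbonyl carbon), the same change made at the same place as between compound 1 and compound 2, while the two cores differ in the way already described for compound 1 and compound 3. Because the earlier instance of this change gave a 1.5-fold higher number from compound 1 to compound 2 (0.19 log units; within the scatter), compound 4 is expected to show a step of about a 1.5-fold higher number from compound 3 to compound 4 (0.18 log units; within the scatter) from compound 3. Compound 4 is therefore estimated at 2100 nM, with a likely range from 1200 nM to 3800 nM.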

Compound 4, half-maximal inhibitory concentration: 8800 nM
For compound 4 the middle estimate is 4.2-fold (0.62 log units) below the measured one; the measured number lies above the stated range.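

In this assay, the exchange of 2,5-dimethoxyphenyl for 2,4-dimethoxyphenyl on the carbonyl carbon gives a 6.3-fold higher number from compound 3 to compound 4 (0.80 log units; beyond the scatter), so the change did not carry over at the size it had on the core of compound 1: the same change on two cores in this assay, a 1.5-fold higher number (0.19 log units; within the scatter) from compound 1 to compound 2 and a 6.3-fold higher number (0.80 log units; beyond the scatter) from compound 3 to compound 4, 4.1-fold (0.61 log units) apart, beyond the scatter of two such steps. Read the other way, the exchange of pyridin-3-yl for pyridin-4-yl gives a 3.8-fold higher number from compound 2 to compound 4 (0.58 log units; beyond the scatter), which does not match the same exchange made with the 2,5-dimethoxyphenyl group in place: the same change on two cores in this assay, a 1.1-fold lower number (0.03 log units; within the scatter) from compound 1 to compound 3 and a 3.8-fold higher number (0.58 log units; beyond the scatter) from compound 2 to compound 4, 4.1-fold (0.61 log units) apart, beyond the scatter of two such steps. The two changes therefore do not add up independently in these four compounds, so a step read on one core is no safe guide to the other, but this single set of four shows neither why the steps part nor whether other changes in the series behave the same way.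

The compounds shown leave open whether a pyridin-2-yl group would show the same dependence on the dimethoxyphenyl pattern. As far as these compounds go, it also remains open whether a 3,4,5-trimethoxyphenyl group would do so on either core.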